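This account rests on a few compounds, and the source may have more. Where it says the series, first, only, none or still open, it means among the compounds named here.

Of the compounds shown here, three have so far been measured in a physicochemical assay for lipophilicity, using the shake flask method, at pH 7.4; a higher number here means a more lipophilic compound, a lower number a more polar compound. Compound 1 `CCCC(Oc1ccc(-n2cc(C(F)(F)F)cn2)c(C)c1)c1ccc(C(=O)NCCC(=O)O)cc1` gives 2.6 in this assay. Compound 2 `CCCC(Oc1ccc(-n2cc(Cl)cn2)cc1)c1ccc(C(=O)NCCC(=O)O)cc1` gives 2.6 in this assay, level with compound 1 at the digits shown and within the scatter of it; together these two give the highest distribution coefficients of the three. Compound 3 `CCCC(Nc1ccc(-n2cc(C(F)(F)F)cn2)nc1)c1ccc(C(=O)NCCC(=O)O)cc1` gives 2.1 in this assay, a number that lies below compound 2 by more than the usual scatter. Among the measured compounds shown here, no two of these measured compounds differ in only one place, so no single step between measured compounds is recorded.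

Compound 4 `CCCC(Oc1ccc(-n2cc(OC)cn2)cc1)c1ccc(C(=O)NCCC(=O)O)cc1` has not yet been measured. It differs from compound 2 in one place: methoxy in place of chloro on an aromatic carbon. For the measured compounds named here, no measured pair shows this same exchange, so the expectation rests on the change itself rather than on a recorded step. In this assay the expected step is a number 0.60 log units lower from compound 2 to compound 4 (beyond the scatter), a decrease that would lie beyond the usual scatter. Compound 4 is therefore expected to give about 2 in this assay, with a range from 1.6 to 2.4.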

Compound 4, distribution coefficient: 1.4
The estimate for compound 4 lay 0.60 log units above the measured number; measured number outside the range, below it.
By their numbers in this assay, from the lowest: compound 4; then compound 3; then compounds 1 and 2 (each within the scatter of the next).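

In this assay, the group on this aromatic carbon of the five-membered ring with two nitrogens clearly matters: methoxy in place of chloro, with the rest of the molecule unchanged, gives a number 1.20 log units lower from compound 2 to compound 4 (beyond the scatter). Among the compounds shown here, this is the first comparison in the set that isolates a single change, as the earlier compounds differ from one another in more than one place and their numbers cannot be assigned to any one group. The change from 4-chloro-1H-pyrazol-1-yl to 4-methoxy-1H-pyrazol-1-yl is small on paper, adding one heavy atom and one hydrogen-bond acceptor with no net charge, yet it comes with a large step.

Nothing measured here accounts for the size of this step. On these data alone, it also remains open whether another group on this carbon, such as an amine, a nitrile or a longer chain ending in the same oxygen link, would give a number closer to that of compound 2 or of compound 4, and whether methoxy in place of chloro would give a step of this size on a different core.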